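The compounds below may be only part of what the source reports. "The series", "measured", "known", "first", "only" and "open" are said of these compounds alone.

Values in a functional assay on MCF7 cells (Homo sapiens) for inhibition, read by sulforhodamine B assay, with a stated time of 48 h; a higher number here means a weaker inhibitor, a lower number a stronger inhibitor:
compound 1 `CCNC(=O)Nc1ccc(/C=C\c2cc(C)cc(C)c2)cc1` gives 17000 nM
compound 2 `Cc1cc(C)cc(/C=C/c2ccc(N3CCNC3=O)cc2)c1` gives 16000 nM

The two values lie within the scatter of each other, so compound 2 stands level with compound 1 in this short set. Compound 3 `Cc1cc(C)cc(/C=C\c2ccc(N3CCNC3=O)cc2)c1` differs from compound 2 in one respect (the two compounds have the same atoms and bonds and differ only in configuration as drawn: 1 of 1 stereo elements differ; a double bond is drawn E in compound 2 and Z in compound 3). Going by the values given here, no measured pair isolates this change. Compound 1, whose double bond is also drawn Z, gives 17000 nM and so offers no sign of a large gain. The expected step of a 1.3-fold lower number from compound 2 to compound 3 (0.12 log units; within the scatter) is small, towards a lower number in this assay and possibly within the scatter. For compound 3 the estimated value is 12000 nM (expected range 4000 nM to 30000 nM).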

Compound 3, half-maximal inhibitory concentration: 23 nM
For compound 3 the middle estimate is 520-fold (2.72 log units) above the measured one; the measured number lies below the stated range.
By their numbers in this assay, from the lowest: compound 3; then compounds 2 and 1 (each within the scatter of the next).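

In this assay, the drawn configuration of the double bond alone accounts for a 700-fold lower number from compound 2 to compound 3 (2.84 log units; beyond the scatter), as one structural fact fixes: the fact that compounds 2 and 3 differ only in the configuration as drawn

A Z double bond is not enough by itself: with that drawing shared, 2-oxoimidazolidin-1-yl in place of (ethylcarbamoyl)amino gives a 740-fold lower number from compound 1 to compound 3 (2.87 log units; beyond the scatter). Among these compounds, the low number therefore appears only where the Z double bond and 2-oxoimidazolidin-1-yl occur together.

Still open, on these data alone, is whether a primary amine or an acetamide in place of 2-oxoimidazolidin-1-yl keeps this level. Also open, as far as these compounds go, is whether methoxy groups can replace the methyl groups.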